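The compounds below may be only part of what the source reports. "The series", "measured", "known", "first", "only" and "open" are said of these compounds alone.

Measured compounds:
compound 1 `CC(C(=O)O)c1ccc(NCc2cccc(Oc3ccccc3)c2)cc1`: 34%
compound 2 `Cc1ccc(CNc2ccc(CCC(=O)O)cc2)cc1`: 152%
compound 3 `O=C(O)CCc1ccc(NCc2cc(C(F)(F)F)cnc2Cl)cc1`: 112%

In a functional assay on CHO cells for agonist activity at Free fatty acid receptor 1 (Homo sapiens), read by reporter gene assay (on this read-out higher numbers stand for larger maximal responses and lower numbers for smaller maximal responses), compound 2 stands highest of the three numbers. Its nearest neighbour is compound 3, whose value lies below it by more than the usual scatter, and the furthest is compound 1, whose value lies below it by a still wider margin, also beyond the scatter. On these three numbers compound 2 therefore gives the largest maximal response.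

Compound 4 `COc1ccc(CNc2ccc(CCC(=O)O)cc2)cc1` is the next to be measured in this assay. It differs from compound 2 in one place: methoxy in place of methyl on an aromatic carbon. Among the compounds with values here, no pair of measured compounds differs by exactly this change, so there is no measured step to lean on; the expectation rests on compound 2 alone. Because compound 2 gives 152% and the change is small, the step from compound 2 to compound 4 is expected to be modest and is estimated at a number 10 percentage points lower from compound 2 to compound 4 (within the scatter), within the usual scatter. Compound 4 is expected to give 142% in this assay, with a range from 105% to 175%.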

Compound 4, largest response reached (reported as percent of maximum), in percent of the reference or control that the assay uses: 159%
Estimate against measurement, compound 4: 17 percentage points below; measured number inside the range.
By their numbers in this assay, from the lowest: compound 1; then compound 3; then compounds 2 and 4 (each within the scatter of the next).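

In this assay, methoxy in place of methyl on an aromatic carbon, para to a large group, gives a number 7 percentage points higher from compound 2 to compound 4 (within the scatter). This first step at this position shows that the maximal response of compound 2 is kept when the methyl gives way to the larger methoxy, which brings an oxygen and a hydrogen-bond acceptor into the place, so a single change here has so far left the read-out within the scatter. Nothing available explains why the two compounds read alike.

Open, as far as these compounds go, is how an ethoxy group, a hydroxyl group, a chlorine atom or an amine at this place would read on the same core. Also open, from the compounds shown here alone, is whether the swap of methyl for methoxy gives a similar step on other cores.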